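This account rests on a few compounds, and the source may have more. Where it says the series, first, only, none or still open, it means among the compounds named here.

The account follows the step from compound 2 to compound 4 in a toxicity assay on THP-1 cells (Homo sapiens) for inhibition; on this read-out higher numbers stand for lower toxicity in this test and lower numbers for higher toxicity in this test. Compound 2 `Cn1c(-c2cccc(Br)c2)cnc1NC(=O)c1ccc(F)cc1` stands in this assay only at a limit, > 50000 nM, which is not a measured number. Compound 1 `Cn1c(-c2cccc([N+](=O)[O-])c2)cnc1NC(=O)c1ccc(F)cc1` likewise gives in this assay only a limit, > 50000 nM. Compound 3 `COc1ccc(-c2nc3ncc(-c4ccc(F)cc4)cc3[nH]2)cc1`, built on a different core, also reaches only a limit in this assay, > 100000 nM. Within the data shown here, two of the three values shown sit at the limit of > 50000 nM in this assay, at which 2 of the 3 values shown sit, and one at the limit of > 100000 nM in this assay, at which 1 of the 3 values shown sits, so no compound here has a readable number. Among the measured compounds shown here, the single step between compounds that differ in one place is a step that the two limits leave unreadable from compound 1 to compound 2, and the two limits leave its size unreadable. Compound 4 `Cn1c(-c2ccc(Br)cc2)cnc1NC(=O)c1ccc(F)cc1` differs from compound 2 in one place: 4-bromophenyl in place of 3-bromophenyl on an aromatic carbon. For the measured compounds named here, no measured step bears on this change with a readable size, and nothing among the measured compounds points in either direction. Compound 4 is therefore expected to show a step that the limit leaves unreadable from compound 2 to compound 4, that is, no step beyond the scatter from compound 2. Compound 4 is estimated at 80000 nM, within a range from 30000 nM to 200000 nM, and is expected most likely to be reported again only as a limit in this assay.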

Compound 4, half-maximal cytotoxic concentration: 46000 nM
Compound 4: the middle estimate sits 1.7-fold (0.24 log units) above what was measured; the measured number falls inside the stated range.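

Compound 4 gives the first readable number in this assay among the compounds shown, 46000 nM, so the series now holds one value that is not a limit. Exchanging 3-bromophenyl for 4-bromophenyl on this aromatic carbon, with the same atoms joined differently, gives an at least 1.0-fold lower number from compound 2 to compound 4 (0.03 log units; that floor lies within the scatter), and a floor of that size does not establish a real difference between the two bromophenyl groups. On these data alone, the true size of this step stays unknown because compound 2 stands only at a limit, not at a number: the limit of > 50000 nM in this assay, at which 2 of the 4 values shown sit.

As far as these compounds go, whether a readable value also appears in this assay with an amine or a carboxylic acid on the phenyl ring in place of the bromine remains open. Also open, from the compounds shown here alone, is whether a longer chain such as propyl, in place of the methyl group on the shared core, would move the number beyond the scatter from compound 4.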